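Replacing a Substituted Urea with a Plain Benzamide

This account rests on a few compounds, and the source may have more. Where it says the series, first, only, none or still open, it means among the compounds named here.

Three compounds have so far been measured in a functional assay on MOLT-4 cells (Homo sapiens) for inhibition, read by sulforhodamine B assay, with a stated time of 48 h; on this read-out higher numbers stand for weaker inhibition of growth and lower numbers for stronger inhibition of growth:
Compound 1 `COc1cc(-c2nn(-c3cccc(NC(=O)c4cccc(C(F)(F)F)c4)c3)cc2-c2ccncc2)ccc1Cl` gives > 50000 nM, which is a limit of the assay rather than a number.
Compound 2 `COc1cc(-c2nn(-c3cccc(NC(=O)c4ccc(Cl)c(C(F)(F)F)c4)c3)cc2-c2ccncc2)ccc1Cl` gives > 32500 nM, also a limit of the assay.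
Compound 3 `COc1cc(-c2nn(-c3cccc(NC(=O)Nc4ccc(Cl)c(C(F)(F)F)c4)c3)cc2-c2ccncc2)ccc1Cl` gives 7960 nM.

Among the compounds with values here, compound 3 therefore stands alone as the only real number among the three; the other two values are only limits, namely the limit of > 50000 nM in this assay, at which 1 of the 3 values shown sits, and (the limit of > 32500 nM in this assay, at which 1 of the 3 values shown sits). The next compound, compound 4 `COc1cc(-c2nn(-c3cccc(NC(=O)c4ccccc4)c3)cc2-c2ccncc2)ccc1Cl`, differs from compound 3 by phenyl in place of (4-chloro-3-(trifluoromethyl)phenyl)amino on a carbonyl carbon. Within the data shown here, two measured steps bear on this change: an at least 6.2-fold lower number from compound 1 to compound 3 (0.79 log units; beyond the scatter) and an at least 4.0-fold lower number from compound 2 to compound 3 (0.61 log units; beyond the scatter). Both run in the opposite direction, from a benzamide to the urea, and each lowered the number at least modestly. Compound 4 reverses the urea and at the same time loses the chloro and trifluoromethyl groups, so a higher number in this assay is expected, probably of at least the size those two steps showed, and quite possibly back at a limit. Compound 4 is therefore expected to give about 40000 nM, with a plausible range from 10000 nM to 100000 nM. The step of a 5.0-fold higher number from compound 3 to compound 4 (0.70 log units; beyond the scatter) is expected to point toward weaker inhibition of growth.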

Compound 4, concentration for total growth inhibition: > 100000 nM
Compound 4 gave a limit, no number; the forecaster's own chance of this, stated with the estimate: 70%; at least 2.5-fold (0.39 log units) between middle value and limit.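

In this assay, putting phenyl on the carbonyl carbon in place of (4-chloro-3-(trifluoromethyl)phenyl)amino gives an at least 12-fold higher number from compound 3 to compound 4 (1.09 log units; beyond the scatter), so a benzamide carrying neither chloro nor trifluoromethyl does not recover the growth inhibition seen with the urea. Compound 4 gives only a limit of the assay, not a number: the limit of > 100000 nM in this assay, at which 1 of the 4 values shown sits. Compounds 1, 2 and 4 are now three benzamides that all end at limits, compound 3 is the only urea and the only one with a real number, and no compound shown goes against this pattern, though the steps among the three benzamides cannot be read.

The change from compound 3 to compound 4 removes the urea nitrogen and the ring's chloro and trifluoromethyl groups together, so these compounds cannot show how much each part contributes. A simple phenylamino group on the carbonyl carbon would separate the urea from the ring substituents, and a 4-methoxyphenylamino or cyclohexylamino group would show how far the number at compound 3 depends on that particular ring.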